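The source may hold more compounds than are shown below. What is called first, only, known or untested is meant among the compounds shown, and "the series" means these compounds.

Of the compounds shown here, three built on one shared core have been tested in an assay on Jurkat E6.1 cells for inhibition of histone deacetylase 4 (Homo sapiens), read by fluorescence; a higher number here means a weaker inhibitor, a lower number a stronger inhibitor. Compound 1 `C[C@H](CN1CCCC(C)(C)C1)NC(=O)c1ccc(-c2noc(C(F)(F)F)n2)cc1` gives 10 nM. Compound 2 `CC(C)(CN1CCCC1)NC(=O)c1ccc(-c2noc(C(F)(F)F)n2)cc1` gives 310 nM, and compound 3 `C[C@H](CN1CCC(F)(F)CC1)NC(=O)c1ccc(-c2noc(C(F)(F)F)n2)cc1` gives 380 nM. Among these three numbers compound 2 stands second highest; its value and that of compound 3 lie within the scatter of each other, while compound 1 stands clearly apart with a lower number. For the measured compounds named here, the only step known so far, a 38-fold higher number from compound 1 to compound 3 (1.58 log units; beyond the scatter), swaps one saturated amine ring for another and leaves untouched the part of the molecule that is changed next. Compound 4 `O=C(NC1(CN2CCCC2)CC1)c1ccc(-c2noc(C(F)(F)F)n2)cc1` differs from compound 2 by 1-((pyrrolidin-1-yl)methyl)cyclopropyl in place of 1-methyl-1-((pyrrolidin-1-yl)methyl)ethyl on an amide-type nitrogen. Going by the values given here, no measured step bears on a change of this kind, so no step beyond the scatter is expected in this assay in either direction, and the estimate has to stay wide. For compound 4 the expected value is 300 nM, within a range from 100 nM to 1000 nM. The expected step, a 1.0-fold lower number from compound 2 to compound 4 (0.01 log units; within the scatter), is therefore small.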

Compound 4, half-maximal inhibitory concentration: 180 nM
Estimate against measurement, compound 4: 1.7-fold (0.22 log units) above; measured number inside the range.
By their numbers in this assay, from the lowest: compound 1; then compounds 4, 2 and 3 (each within the scatter of the next, the first and the last beyond it).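

Exchanging 1-methyl-1-((pyrrolidin-1-yl)methyl)ethyl for 1-((pyrrolidin-1-yl)methyl)cyclopropyl on the amide-type nitrogen gives a 1.7-fold lower number from compound 2 to compound 4 (0.24 log units; within the scatter) in this assay. The two groups have the same heavy-atom count, and the entering group adds a three-membered carbon ring, so for this pair, closing that ring leaves no change that can be told from the scatter. Nothing available explains this result.

On these data alone, it remains open whether a cyclobutyl ring in the same place would also leave the number within the scatter. As far as these compounds go, it is also open whether the 3,3-dimethylpiperidin-1-yl ring of compound 1, put in place of the pyrrolidine ring on the cyclopropyl group, would give a number different from that of compound 4.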